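The compounds below may be only part of what the source reports. "The series", "measured", "known", "first", "only" and "open" are said of these compounds alone.

Compound 1 `CN(C[C@H]1Cc2c(cccc2N2CCNC(C)(C)C2)CN1)[C@H]1CCCc2cccnc21` was tested in a functional assay on CCRF-CEM cells for agonist activity at C-X-C chemokine receptor type 4 (Homo sapiens), read by calcium flux, with a stated time of 25 min (on this read-out lower numbers stand for an effect already at smaller amounts and higher numbers for an effect only at larger amounts of compound), and gave no number there: the value of compound 1, > 30000 nM, is a limit of the assay. Compound 2 `CN(C[C@H]1Cc2c(cccc2N2CCN(c3cccc(C(F)(F)F)c3)CC2)CN1)[C@H]1CCCc2cccnc21` fared the same way in this assay, where compound 2 gave > 30000 nM, likewise a limit. Thus compound 1 stands nowhere in particular on the numbers shown; both values sit at the same limit (the limit of > 30000 nM in this assay, at which 2 of the 2 values shown sit), and neither compound can be placed above or below the other.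

Compound 3 `C[C@@H]1CN(c2cccc3c2C[C@H](CN(C)[C@H]2CCCc4cccnc42)NC3)C[C@H](C)N1C` keeps the shared core of compound 1 and carries one change, (3,4,5-trimethylpiperazin-1-yl in place of 3,3-dimethylpiperazin-1-yl on an aromatic carbon). Among the compounds with values here, since no step between measured compounds is at hand, there is no measured size to lean on. The expectation is that compound 3 behaves like compound 1 in this assay, with a step from compound 1 to compound 3 of a step that the limit leaves unreadable from compound 1 to compound 3, which is within the scatter and most likely again a limit. Compound 3 is therefore estimated at 40000 nM, with a range from 8000 nM to 200000 nM.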

Compound 3, half-maximal effective concentration: > 30000 nM
Compound 3 ended at the assay's limit; the forecaster's own chance of this, stated with the estimate: 80%; the middle value lies beyond the limit too.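

Compound 3 in this assay gives > 30000 nM as a limit of the assay. No step can be read between compound 1 and compound 3, which sit at the same limit: the limit of > 30000 nM in this assay, at which 3 of the 3 values shown sit. The compounds shown leave open how they rank against one another in this assay and whether any change on the shared core gives a readable number.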